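A few compounds are considered here, and "the series" means these few. Any claim that something is new, unique, unknown or untested is made for them only; others in the source may bear on it.

Measured so far:
Compound 1 `COc1cc2cc(C(=O)CCC3CC[N+](C)(Cc4ccccc4)CC3)sc2cc1OC` gives 2000 ug/mL in a physicochemical assay for solubility; a lower number here means a less soluble compound, a higher number a more soluble compound.
Compound 2 `COc1cc2cc(C(=O)C=C3CC[N+](C)(Cc4ccccc4)CC3)sc2cc1OC` gives 25000 ug/mL.
Compound 3 `CC[n+]1ccc(CCC(=O)c2cc3cc(OC)c(OC)cc3s2)cc1` gives 25000 ug/mL.

Compound 3 stands level with compound 2 at the digits shown, the two together the highest of the three numbers, and the gap between them lies within the usual scatter. Compound 1 stands furthest off, with a lower number that lies beyond the scatter.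

Compound 4 `COc1cc2cc(C(=O)CCc3cc[n+](CC4CCC4)cc3)sc2cc1OC` differs from compound 3 in one place: cyclobutyl in place of methyl on a saturated chain carbon bound to an aromatic nitrogen. Among the measured compounds shown here, no step between measured compounds resembles this change, so the expectation rests on the change itself, which puts a four-membered carbon ring where a methyl stood. A modest drop in this assay is expected, as a 2.1-fold lower number from compound 3 to compound 4 (0.32 log units; beyond the scatter). Compound 4 is expected to give 12000 ug/mL, with a range from 4000 ug/mL to 25000 ug/mL.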

Compound 4, solubility: 6000 ug/mL
The estimate for compound 4 lay 2.0-fold (0.30 log units) above the measured number, and the stated range covers the measured number.
By their numbers in this assay, from the lowest: compound 1; then compound 4; then compounds 2 and 3 (each within the scatter of the next).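

In this assay, cyclobutyl in place of methyl on a saturated chain carbon bound to an aromatic nitrogen gives a 4.2-fold lower number from compound 3 to compound 4 (0.62 log units; beyond the scatter), a modest step. This single pair shows that the number responds to a change at this position, with four heavy atoms in a ring replacing one, yet compound 4 still reads 6000 ug/mL in this assay. No available evidence bears on why the number falls. As far as these compounds go, whether the ring or simply the added carbons matter stays open, as does the effect of an open butyl chain, an amine or a carboxylic acid at this place.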